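This account rests on a few compounds, and the source may have more. Where it says the series, first, only, none or still open, it means among the compounds named here.

In a functional assay on GC3/C1 cells (Homo sapiens) for cytotoxicity, read by MTT assay, with a stated time of 6 days (on this read-out lower numbers stand for stronger inhibition and higher numbers for weaker inhibition), compound 2 `CC(=O)N[C@@H](CSC(=O)Nc1ccccc1Cl)C(=O)O` gives > 200000 nM, which is a limit and not a number. Compound 1 `CC(=O)N[C@@H](CSC(=O)Nc1ccccc1F)C(=O)O` gives > 200000 nM, also a limit. Compound 3 `CC(=O)N[C@@H](CSC(=O)Nc1ccccc1)C(=O)O`, with hydrogen where those two carry a halogen, gives an actual number, 178000 nM. Compound 2 therefore has no exact place on the scale and stands at the limit of > 200000 nM in this assay, at which 2 of the 3 values shown sit.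

Compound 4 `CC(=O)N[C@@H](CSC(=O)Nc1ccc([N+](=O)[O-])cc1Cl)C(=O)O` differs from compound 2 by nitro in place of hydrogen on an aromatic carbon. Three measured changes on the aromatic ring bear on this. Swapping one halogen for the other gives a step that the two limits leave unreadable from compound 1 to compound 2. Replacing the halogen with hydrogen gives an at least 1.1-fold lower number from compound 2 to compound 3 (0.05 log units; that floor lies within the scatter) and an at least 1.1-fold lower number from compound 1 to compound 3 (0.05 log units; that floor lies within the scatter), and both floors lie within the scatter. None of these compounds carries a nitro, so these steps set no size for the new change. Since compound 3 gives 178000 nM, numbers in this small set stay high, and only a modest move is expected. The expected change is an at least 2.0-fold lower number from compound 2 to compound 4 (0.30 log units; that floor lies within the scatter), toward a lower number in this assay. For compound 4 the estimated value is 100000 nM, with an expected range from 25000 nM to 250000 nM.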

Compound 4, half-maximal inhibitory concentration: > 200000 nM
Compound 4: a limit, no number; the forecaster's own chance of this, stated with the estimate: 35%; middle value at least 2.0-fold (0.30 log units) from the limit.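

In this assay compound 4 gives > 200000 nM, which is a limit and not a number. Compound 2 also gives only a limit, so the step between compound 2 and compound 4 cannot be read. On these data alone, whether nitro in place of hydrogen shifts the number at all stays open.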